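Anilide with phenol in place of the cysteine ester

The source may report more compounds than this note shows. Statements on the series, on what has been measured and on what is new or still open speak of the compounds shown alone.

Within the data shown here, in a functional assay on CLL cells (Homo sapiens) for cytotoxicity, read by MTT assay, with a stated time of 48 h (on this read-out lower numbers stand for an effect already at smaller amounts and higher numbers for an effect only at larger amounts of compound), compound 1 `C=C(CC)C(=O)c1ccc(OCC(=O)NC(CS)C(=O)OCC)c(Cl)c1Cl` gives 4800 nM, the second highest of the three numbers so far. Compound 2 `C=C(CC)C(=O)c1ccc(OCC(=O)Nc2ccc(C(=O)NC(CCC(=O)OCC)C(=O)OCC)cc2)c(Cl)c1Cl` gives 2100 nM, a lower number beyond the scatter, while compound 3 `C=C(CC)C(=O)c1ccc(OCC(=O)NC2CCN(CC(=O)OC)CC2)c(Cl)c1Cl` gives 10600 nM, a higher number beyond the scatter. Compound 4 `C=C(CC)C(=O)c1ccc(OCC(=O)Nc2ccc(O)cc2)c(Cl)c1Cl` is not yet measured; it differs from compound 1 in one place: 4-hydroxyphenyl in place of 1-(ethoxycarbonyl)-2-sulfanylethyl on an amide-type nitrogen. The change removes the ethoxycarbonyl group carried by compound 1 and compound 3 and brings in an aromatic ring on the amide-type nitrogen, as compound 2 has. The step of a 1.6-fold lower number from compound 1 to compound 4 (0.20 log units; within the scatter) is expected to be modest and toward a lower number, because compound 2 gives 2100 nM. Compound 4 is estimated at 3000 nM, with a range from 1200 nM to 8000 nM.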

Compound 4, half-maximal effective concentration: 6400 nM
Compound 4: the middle estimate sits 2.1-fold (0.33 log units) below what was measured; low and high end bracket the measured number.
By their numbers in this assay, from the lowest: compound 2; then compounds 1, 4 and 3 (each within the scatter of the next, the first and the last beyond it).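

In this assay, 4-hydroxyphenyl in place of 1-(ethoxycarbonyl)-2-sulfanylethyl on the amide-type nitrogen gives a 1.3-fold higher number from compound 1 to compound 4 (0.12 log units; within the scatter). At this position, this exchange of an open chain for an aromatic ring therefore leaves no difference that the assay can resolve. No available data bear on why the two compounds read alike.

Open, as far as these compounds go, is what the hydroxyl of the 4-hydroxyphenyl group contributes, which an amine or a carboxylic acid in its place would test. Also open, from the compounds shown here alone, is how the sulfanyl and ethoxycarbonyl parts of compound 1 each contribute.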